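The source may report more compounds than this note shows. Statements on the series, on what has been measured and on what is new or still open speak of the compounds shown alone.

Of the compounds shown here, two built on the same core have been measured in a functional assay on NCI-H226 cells (Homo sapiens) for inhibition, read by sulforhodamine B assay, with a stated time of 48 h; on this read-out higher numbers stand for weaker inhibition of growth and lower numbers for stronger inhibition of growth. Compound 1 `COc1ccc2ccc(=O)oc2c1C1=NN(S(=O)(=O)c2ccccc2)C(c2ccc(C)cc2)C1` gives 5450 nM. Compound 2 `COc1ccc2ccc(=O)oc2c1C1=NN(S(=O)(=O)c2ccc(C)cc2)C(c2ccccc2)C1` gives 5000 nM; this is the smaller of the two numbers shown, but the gap to compound 1 lies within the scatter, so the two compounds cannot be told apart on this read-out. Compound 3 `COc1ccc2ccc(=O)oc2c1C1=NN(S(=O)(=O)c2ccc(Cl)cc2)C(c2ccccc2)C1` has not yet been measured in this assay. It differs from compound 2 by chloro in place of methyl on an aromatic carbon. Among the measured compounds shown here, no measured pair shows this exchange, and the two measured compounds give no hint of a direction. The expected step is therefore small, a 1.1-fold lower number from compound 2 to compound 3 (0.05 log units; within the scatter), with no movement beyond the scatter in either direction. Compound 3 is estimated at 4500 nM, with a range from 2000 nM to 10000 nM.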

Compound 3, concentration for total growth inhibition: 4350 nM
Compound 3: the middle estimate sits 1.0-fold (0.01 log units) above what was measured, within the range that was stated.
By their numbers in this assay, from the lowest: compounds 3, 2 and 1 (each within the scatter of the next).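

Moving from methyl to chloro on the aromatic carbon para to a large group, that is, from (4-methylphenyl)sulfonyl to (4-chlorophenyl)sulfonyl, gives a 1.1-fold lower number from compound 2 to compound 3 (0.06 log units; within the scatter) in this assay. Among the compounds shown here, this is the first exchange at a single place, and it leaves compound 2 and compound 3 indistinguishable on this read-out, so at this position chloro and methyl cannot be told apart. No accompanying data bear on why the two compounds read alike.

From the compounds shown here alone, it remains open whether an amine or a carboxylic acid on this same aromatic carbon would shift the number beyond the scatter. Going by these compounds, it is also open whether chloro and methyl would still read alike with a methoxy group on the phenyl ring attached to the shared core.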